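Swapping Nitro for Bromo on the Sulfonyl Ring

The compounds below may be only part of what the source reports. "The series", "measured", "known", "first", "only" and "open" are said of these compounds alone.

Measured so far:
Compound 1, `CCCCNC(=S)NC1=C(C#N)C(c2ccc(Cl)cc2Cl)C2=C(CCCC2=O)N1c1ccc(S(N)(=O)=O)cc1`, gives 30% in a functional assay on Ehrlich cells (Mus musculus) for cytotoxicity, read by trypan blue exclusion, with a stated time of 2 h, tested at 25 ug/mL; on this read-out lower numbers stand for a weaker effect and higher numbers for a stronger effect at the one concentration tested.
Compound 2, `N#CC1=C(NS(=O)(=O)c2ccc([N+](=O)[O-])cc2)N(c2ccc(S(N)(=O)=O)cc2)C2=C(C(=O)CCC2)C1c1ccc(Cl)cc1Cl`, gives 85% in this assay.

Within the data shown here, compound 2 stands highest of the two numbers in this assay; its only neighbour is compound 1, separated by a number 55 percentage points higher from compound 1 to compound 2 (beyond the scatter). Compound 3, `N#CC1=C(NS(=O)(=O)c2ccc(Br)cc2)N(c2ccc(S(N)(=O)=O)cc2)C2=C(C(=O)CCC2)C1c1ccc(Cl)cc1Cl`, is not yet measured. It differs from compound 2 by bromo in place of nitro on an aromatic carbon. Among the measured compounds shown here, the single measured step, a number 55 percentage points higher from compound 1 to compound 2 (beyond the scatter), exchanges a whole group on an amine nitrogen; no measured step touches a substituent on this aromatic ring. The expected step is modest, a number 15 percentage points lower from compound 2 to compound 3 (beyond the scatter), downward or none beyond the scatter. Compound 3 is expected to give 70%, between 45% and 90%.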

Compound 3, a percentage reported as activity, at one concentration (the size of the read-out at that concentration, not a potency): 90%
The estimate for compound 3 lay 20 percentage points below the measured number; measured number inside the range.
By their numbers in this assay, from the lowest: compound 1; then compounds 2 and 3 (each within the scatter of the next).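

Exchanging nitro for bromo on this aromatic carbon, para to a large group, gives a number 5 percentage points higher from compound 2 to compound 3 (within the scatter) in this assay, so the read-out does not separate these two groups. The large gain seen earlier therefore does not depend on the nitro group, since a number 60 percentage points higher from compound 1 to compound 3 (beyond the scatter) is found with the (4-bromophenyl)sulfonyl group in its place. Nothing available explains why the two groups read alike.

Only these two groups have been seen at this position. On these data alone, how an amine or a methoxy group would read here remains open, as does a ring carrying hydrogen alone.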